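The compounds below may be only part of what the source reports. "The series", "measured", "known", "first", "only" and "open" are said of these compounds alone.

Measured in a functional assay on a cell-free system (plasma, Homo sapiens), with a stated time of 3 min; a lower number here means a stronger inhibitor, a higher number a weaker inhibitor
- compound 1 `O=C(NCc1cc(Cl)ccc1-n1cnnn1)[C@@H]1C[C@@H]2C[C@@H]2N1C(=O)[C@H](O)c1cccc(Cl)c1` gives 1000 nM
- compound 2 `O=C(NCc1cc(Cl)ccc1-n1cnnn1)[C@@H]1C[C@@H]2C[C@@H]2N1C(=O)[C@H](O)C1CCCCC1` gives 600 nM
- compound 3 `CC(C)(C)[C@@H](O)C(=O)N1[C@H](C(=O)NCc2cc(Cl)ccc2-n2cnnn2)C[C@@H]2C[C@@H]21` gives 1500 nM

Compound 3 sits with compound 1 at the high-number end of this small set (a 1.5-fold higher number from compound 1 to compound 3 (0.18 log units; within the scatter)) and apart from compound 2 (a 2.5-fold higher number from compound 2 to compound 3 (0.40 log units; beyond the scatter)). Compound 4 `CC(C)(C)C[C@@H](O)C(=O)N1[C@H](C(=O)NCc2cc(Cl)ccc2-n2cnnn2)C[C@@H]2C[C@@H]21` carries neopentyl in place of tert-butyl on a saturated chain carbon bound to a carbonyl carbon and an oxygen on a saturated carbon. Earlier swaps at this same place moved the number little: cyclohexyl for 3-chlorophenyl stayed within the scatter (a 1.7-fold lower number from compound 1 to compound 2 (0.22 log units; within the scatter)), and the two tert-butyl steps were modest at most. No step beyond the scatter is therefore expected (a 1.5-fold lower number from compound 3 to compound 4 (0.18 log units; within the scatter)). For compound 4 the estimated value is 1000 nM (expected range 450 nM to 2200 nM).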

Compound 4, half-maximal inhibitory concentration: 570 nM
For compound 4 the middle estimate is 1.8-fold (0.24 log units) above the measured one; measured number inside the range.
By their numbers in this assay, from the lowest: compounds 4, 2, 1 and 3 (each within the scatter of the next, the first and the last beyond it).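

In this assay neopentyl in place of tert-butyl gives a step beyond the scatter (a 2.6-fold lower number from compound 3 to compound 4 (0.42 log units; beyond the scatter)), so this position responds even to a swap between two ring-free groups. Compound 4 stays within the scatter of the ring-bearing compounds (a 1.1-fold lower number from compound 2 to compound 4 (0.02 log units; within the scatter); a 1.8-fold lower number from compound 1 to compound 4 (0.24 log units; within the scatter)), so a ring is not required here for a value like theirs. Nothing measured here accounts for the neopentyl step.

A longer chain could continue this trend or reverse it. On these data alone, how an amine or a carboxylic acid would read at this place also remains open.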